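Swapping the nitrogen substituent on the benzimidazole-acid series

A few compounds are considered here, and "the series" means these few. Any claim that something is new, unique, unknown or untested is made for them only; others in the source may bear on it.

Measured so far in an assay on Huh-7 cells for agonist activity at Bile acid receptor (Homo sapiens), read by a luciferase reporter; on this read-out lower numbers stand for an effect already at smaller amounts and higher numbers for an effect only at larger amounts of compound:
compound 1 `CCC(CC)n1c(-c2ccc(OCc3c(-c4c(Cl)cccc4Cl)noc3C(C)C)cc2F)nc2ccc(C(=O)O)cc21`: 1.3 nM
compound 2 `CC(C)c1onc(-c2c(Cl)cccc2Cl)c1COc1ccc(-c2nc3ccc(C(=O)O)cc3n2CC2CCCCC2)c(F)c1`: 7.8 nM
compound 3 `CC(C)c1onc(-c2c(Cl)cccc2Cl)c1COc1ccc(-c2nc3ccc(C(=O)O)cc3n2CC(C)(C)C)cc1`: 13 nM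

Compound 3 has the highest number of the three. Against compound 2 the gap is within the scatter, so no order between the two can be read; against compound 1 it is beyond the scatter. Within the data shown here, the only single-point step recorded is a 6.0-fold higher number from compound 1 to compound 2 (0.78 log units; beyond the scatter), a move from one branched alkyl group to another on the ring nitrogen. Compounds 2 and 3 differ in more than one place, so their values show only that both sit well above compound 1.

Compound 4 `CC(C)c1onc(-c2c(Cl)cccc2Cl)c1COc1ccc(-c2nc3ccc(C(=O)O)cc3n2-c2ccc(F)cc2)cc1` carries the change (4-fluorophenyl in place of neopentyl on an aromatic nitrogen). Among the measured compounds shown here, no measured pair exchanges an alkyl group for an aromatic ring at this nitrogen, so the direction is open; the one alkyl-to-alkyl step there was modest and went to a higher number. A step of similar size in either direction is therefore plausible, and the estimate is centred a little above compound 3, with wide bounds. For compound 4 the expected value is 25 nM, within 6 nM to 100 nM. The expected step is a 1.9-fold higher number from compound 3 to compound 4 (0.28 log units; within the scatter).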

Compound 4, half-maximal effective concentration: 32.2 nM
Beside the measured number, compound 4's estimate is 1.3-fold (0.11 log units) below it; measured number inside the range.
By their numbers in this assay, from the lowest: compound 1; then compounds 2 and 3 (each within the scatter of the next); then compound 4.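

Among these compounds, this is the first exchange of an alkyl group for an aromatic ring on this nitrogen, and in this assay it gives a 2.5-fold higher number from compound 3 to compound 4 (0.39 log units; beyond the scatter), a modest step beyond the scatter. Among the compounds shown here, an aryl group is therefore accommodated here, with compound 4 still at 32.2 nM, and both steps readable at this nitrogen, this one and a 6.0-fold higher number from compound 1 to compound 2 (0.78 log units; beyond the scatter), go to higher numbers, with no compound going against that so far. Nothing available explains the rise in the number.

From the compounds shown here alone, the share of the ring itself and of its fluorine in this step stays open, and a plain phenyl or a pyridine ring at this nitrogen would separate the two. Going by these compounds, it is also open whether pentan-3-yl, the group on compound 1, would give a lower number on the core of compound 3.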